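The source may report more compounds than this note shows. Statements on the series, on what has been measured and on what is new or still open speak of the compounds shown alone.

In an ADME assay on WI-38 cells (Homo sapiens) for cytotoxicity, read by MTT assay, with a stated time of 72 h (a higher number here means a weaker inhibitor, a lower number a stronger inhibitor), compound 3 `O=C(CCc1cccc2c1B(O)OC2)Nc1ccc(Br)cc1` gives 42000 nM, and compound 1 `O=C(CCc1cccc2c1B(O)OC2)Nc1ccccc1` gives 30000 nM. Compound 2 `O=C(CCc1cccc2c1B(O)OC2)Nc1nccs1` returns only a limit, > 100000 nM. Compound 4 `O=C(CCc1cccc2c1B(O)OC2)Nc1cccc(I)c1` has 3-iodophenyl in place of 4-bromophenyl on the amide-type nitrogen: 3-iodophenyl in place of 4-bromophenyl on an amide-type nitrogen. Two kinds of measured step bear on this change. Adding bromo to the phenyl gave a 1.4-fold higher number from compound 1 to compound 3 (0.15 log units; within the scatter), whereas leaving the phenyl series for 1,3-thiazol-2-yl gave an at least 3.3-fold higher number from compound 1 to compound 2 (0.52 log units; beyond the scatter) and returning gave an at least 2.3-fold lower number from compound 2 to compound 3 (0.37 log units; beyond the scatter). Compound 4 stays a halogen-bearing phenyl amide, so only the bromo step is a close guide, and no change beyond the scatter is expected in this assay. The expected change is a 1.2-fold lower number from compound 3 to compound 4 (0.08 log units; within the scatter). For compound 4 the estimated value is 35000 nM, with an expected range of 15000 nM to 80000 nM.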

Compound 4, half-maximal inhibitory concentration: 71000 nM
The estimate for compound 4 lay 2.0-fold (0.31 log units) below the measured number; low and high end bracket the measured number.
By their numbers in this assay, from the lowest: compounds 1, 3 and 4 (each within the scatter of the next, the first and the last beyond it). At a limit, above all of these: compound 2.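

In this assay, iodo in place of hydrogen on the phenyl gives a 2.4-fold higher number from compound 1 to compound 4 (0.37 log units; beyond the scatter), so this halogen step leaves the scatter where the bromo step did not. The exchange itself gives a 1.7-fold higher number from compound 3 to compound 4 (0.23 log units; within the scatter), so 3-iodophenyl and 4-bromophenyl are not separated here. The remaining step, an at least 1.4-fold lower number from compound 2 to compound 4 (0.14 log units; that floor lies within the scatter), starts from a limit and gives only a floor: the limit of > 100000 nM in this assay, at which 1 of the 4 values shown sits.

Open, going by these compounds, is whether the halogen or its place on the phenyl sets the number, a question that 4-iodophenyl and 3-bromophenyl amides would separate. Also open, on these data alone, is how an amine on the phenyl would read.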